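Furan isomer swap in a dihydropyrimidinone ester series

The source may hold more compounds than are shown below. What is called first, only, known or untested is meant among the compounds shown, and "the series" means these compounds.

Measured so far:
compound 1 `CC1=C(C(N)=O)C(c2ccoc2)NC(=O)N1`: 2%
compound 2 `CC1=C(C(=O)OCC2CC2)C(c2ccco2)NC(=O)N1`: 1%

In an assay on membranes from HeLa cells for displacement of a labelled ligand from adenosine receptor A3 (Homo sapiens), read by scintillation counting, with a stated time of 180 min, tested at 1 uM (a higher number here means more inhibition at the concentration tested (going by the name of the read-out), a lower number less inhibition), compound 1 gives 2% and compound 2 gives 1%. Compound 2 holds the lowest of the two numbers, but the gap to compound 1 lies within the scatter, so the two read as the same. Both stand near the floor of the read-out.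

The next compound, compound 3 `CC1=C(C(=O)OCC2CC2)C(c2ccoc2)NC(=O)N1`, keeps the cyclopropylmethyl ester of compound 2 and differs only in the furan: furan-3-yl in place of furan-2-yl on a saturated ring carbon. The same atoms are joined differently, with the ring oxygen moved within the five-membered aromatic ring.

For the measured compounds named here, no measured pair isolates this furan-2-yl to furan-3-yl exchange. Compound 1 carries the furan-3-yl already and sits at 2%, so nothing among the numbers suggests that this ring alone lifts inhibition. The expected step of a number 1 percentage points higher from compound 2 to compound 3 (within the scatter) is therefore none beyond the scatter. Compound 3 is estimated at 2%, with a range from -8% to 12%.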

Compound 3, a percentage reported as inhibition, at one concentration (the size of the read-out at that concentration, not a potency): 3%
Compound 3: the middle estimate sits 1 percentage points below what was measured; the measured number falls inside the stated range.
By their numbers in this assay, from the lowest: compounds 2, 1 and 3 (each within the scatter of the next).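

In this assay, the furan-3-yl for furan-2-yl exchange on the saturated ring carbon, with the cyclopropylmethyl ester held constant, can now be read directly as a number 2 percentage points higher from compound 2 to compound 3 (within the scatter) and does not separate the two isomers. The carbonyl carbon gets its first reading as well: cyclopropylmethoxy in place of amino, with furan-3-yl held constant, gives a number 1 percentage points higher from compound 1 to compound 3 (within the scatter) and does not separate that pair either. Nothing available on these compounds bears on the reason for these results.

All three compounds sit near the floor of the read-out at this single concentration, so neither exchange shows whether these two places matter for inhibition. On these data alone, it remains open whether a phenyl ring on the saturated ring carbon, or a carboxylic acid or a longer chain ester on the carbonyl carbon, would give a number clear of the scatter.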